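This account rests on a few compounds, and the source may have more. Where it says the series, first, only, none or still open, it means among the compounds named here.

In a physicochemical assay for solubility, in phosphate buffer, measured as kinetic solubility, with a stated time of 1 h, at pH 7.4 (on this read-out higher numbers stand for higher solubility and lower numbers for lower solubility), compound 1 `COc1ccc2nc(C)cc(NCC(=O)Nc3cc(C)cc(C)c3)c2c1` gives 204000 nM, while compound 2 `COc1cccc(NC(=O)COc2cc(C)nc3ccc(OC)cc23)c1` gives 35000 nM. Compound 2 therefore stands lowest of the two numbers in hand, and compound 1 sits higher by a gap beyond the usual scatter. Among the compounds with values here, no single-point step between measured compounds is available, as compound 1 and compound 2 differ in more than one place, so the two values are noted side by side only. Compound 3 `COc1ccc2nc(C)cc(OCC(=O)Nc3nccs3)c2c1` departs from compound 2 at one position: 1,3-thiazol-2-yl in place of 3-methoxyphenyl on an amide-type nitrogen. The rest of compound 2, including its link to the shared core, is kept. Without a measured step of this kind, the step of a 2.0-fold higher number from compound 2 to compound 3 (0.30 log units; within the scatter) is expected to be a modest rise in this assay, around the edge of the scatter rather than clearly beyond it. Compound 3 is estimated at 70000 nM in this assay, with a range from 20000 nM to 250000 nM.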

Compound 3, solubility: 54000 nM
Beside the measured number, compound 3's estimate is 1.3-fold (0.11 log units) above it; the measured number falls inside the stated range.
By their numbers in this assay, from the lowest: compounds 2 and 3 (each within the scatter of the next); then compound 1.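

Working notes on the group on the amide-type nitrogen: in this assay, 1,3-thiazol-2-yl in place of 3-methoxyphenyl gives a 1.5-fold higher number from compound 2 to compound 3 (0.19 log units; within the scatter). Within the data shown here, this is the first single-place reading, and it shows that a five-membered aromatic ring with 2 hetero atoms can stand at this position in place of a six-membered aromatic ring of carbon only without the two numbers separating beyond the scatter. No measured evidence bears on why the two numbers stay this close.

On these data alone, whether an aliphatic amine or a carboxylic acid on this amide-type nitrogen would move the number beyond the scatter remains open. Compound 1, at 204000 nM, differs from compound 2 in more than one place, and what any single part of its structure contributes is still unresolved.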